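A few compounds are considered here, and "the series" means these few. Any claim that something is new, unique, unknown or untested is made for them only; others in the source may bear on it.

Measured in a physicochemical assay for solubility, read by HPLC, in phosphate buffer, measured as kinetic solubility, with a stated time of 1 h, at pH 7.4, tested at 250 uM; on this read-out lower numbers stand for lower solubility and higher numbers for higher solubility:
- Compound 1 `COc1cc(-c2cn(C(=O)NCCCCc3ccccc3)c(=O)o2)ccc1F`: < 1000 nM
- Compound 2 `CN1CCC(c2cccc(-c3cn(C(=O)NCCCCc4ccccc4)c(=O)o3)c2)CC1`: 70000 nM

The value of compound 1 is a limit of the assay and not a number. Going by the values given here, compound 2, at 70000 nM, therefore holds the only number available. Compound 3 `CN1CCC(c2cc(-c3cn(C(=O)NCCCCc4ccccc4)c(=O)o3)ccc2F)CC1` differs from compound 2 by fluoro in place of hydrogen on an aromatic carbon, ortho to a 1-methylpiperidin-4-yl group and para to a large group: fluoro in place of hydrogen on an aromatic carbon. Among the compounds with values here, no measured step shows what such a change does in this assay, so only a small fall, hardly beyond the usual scatter, is expected. The expected change is a 1.3-fold lower number from compound 2 to compound 3 (0.10 log units; within the scatter). Compound 3 is estimated at 55000 nM, with an expected range of 22000 nM to 120000 nM.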

Compound 3, solubility: 30000 nM
Compound 3: the middle estimate sits 1.8-fold (0.26 log units) above what was measured, and the stated range covers the measured number.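

In this assay, fluoro in place of hydrogen on this aromatic carbon, ortho to the 1-methylpiperidin-4-yl group, gives a 2.3-fold lower number from compound 2 to compound 3 (0.37 log units; beyond the scatter), so the change is modest but not silent. With the fluoro present in both compounds, 1-methylpiperidin-4-yl in place of methoxy gives an at least 30-fold higher number from compound 1 to compound 3 (1.47 log units; beyond the scatter). Compound 1 stands at a limit of the assay and not at a number: the limit of < 1000 nM in this assay, at which 1 of the 3 values shown sits. The compounds shown leave open whether chloro on that carbon would lower the number as far. They also leave open whether a morpholine in place of 1-methylpiperidin-4-yl would hold it up.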